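The compounds below may be only part of what the source reports. "The series", "measured", "known", "first", "only" and "open" are said of these compounds alone.

Measured compounds:
Compound 1, `COc1ccc2nc(-c3ccc(N/C=C\C(=O)c4ccc(OC)c(O)c4)c(C)c3)sc2c1`, in a functional assay on MDA-MB-231 cells (Homo sapiens) for antiproliferative activity, read by sulforhodamine B assay, with a stated time of 48 h (on this read-out higher numbers stand for weaker inhibition and lower numbers for stronger inhibition), compound 1 gives 14000 nM.
Compound 2, `COc1ccc2nc(-c3ccc(N/C=C\C(=O)c4ccc(OC)c(O)c4)cc3)sc2c1`, in this assay compound 2 gives 18900 nM.
Compound 3, `COc1cc(OC)c2sc(-c3ccc(N/C=C\C(=O)c4cc(OC)c(OC)c(OC)c4)c(C)c3)nc2c1`, in this assay compound 3 gives 13800 nM.

Compound 1 and compound 2 differ by one change, (hydrogen in place of methyl on an aromatic carbon), and this change made a step of a 1.4-fold higher number from compound 1 to compound 2 (0.13 log units; within the scatter). Compound 4, `COc1cc(OC)c2sc(-c3ccc(N/C=C\C(=O)c4cc(OC)c(OC)c(OC)c4)cc3)nc2c1`, has not yet been measured in this assay. It stands to compound 3 as compound 2 stands to compound 1: the change is hydrogen in place of methyl on an aromatic carbon, the same change made on the other core. The difference between the two cores, that of compound 1 and that of compound 3, is not broken down here. Because the earlier step of a 1.4-fold higher number from compound 1 to compound 2 (0.13 log units; within the scatter) stayed within the scatter, the step from compound 3 to compound 4 is expected to be small as well, estimated as a 1.3-fold higher number from compound 3 to compound 4 (0.12 log units; within the scatter). Compound 4 is therefore estimated to give 18000 nM in this assay, with a range from 9000 nM to 36000 nM.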

Compound 4, half-maximal inhibitory concentration: 15800 nM
Estimate against measurement, compound 4: 1.1-fold (0.06 log units) above; the measured number falls inside the stated range.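

In this assay, hydrogen in place of methyl on an aromatic carbon gave a 1.1-fold higher number from compound 3 to compound 4 (0.06 log units; within the scatter) on the second core. The steps on the two cores do not differ beyond what repeated measurements would give: the same change on two cores in this assay, a 1.4-fold higher number (0.13 log units; within the scatter) from compound 1 to compound 2 and a 1.1-fold higher number (0.06 log units; within the scatter) from compound 3 to compound 4, 1.2-fold (0.07 log units) apart, within the scatter of two such steps. For the compounds shown here, the change thus stays within the scatter on both cores, but this shows only that neither step can be told from no step, not that the methyl has any effect, and it rests on just these two pairs.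

The compounds shown leave open whether another group at this place, such as an ethyl, a chlorine or an amine, would give a larger step. They also leave open whether the same small step would hold on other cores.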